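Substituent swap on the phenyl ring of a shared core

The source may report more compounds than this note shows. Statements on the series, on what has been measured and on what is new or still open speak of the compounds shown alone.

Measured compounds:
compound 1 `SC1=NC(n2nc(-c3ccccc3)nc2-c2ccccc2)=CC(c2ccc(Cl)cc2)N1` gives 300 mg/kg
compound 2 `SC1=NC(n2nc(-c3ccccc3)nc2-c2ccccc2)=CC(c2ccc(-c3ccco3)cc2)N1` gives 300 mg/kg

In a functional assay on the whole organism with Mus musculus as the target, in the maximal electroshock model, with a stated time of 4 h (a higher number here means that more compound is needed for the effect, a lower number that less compound is needed), compound 2 stands level with compound 1 at the digits shown, within the scatter; the step of no change at the digits printed from compound 1 to compound 2 (within the scatter) is the only measured step and it bears directly on the change now considered, since it sits on the same aromatic carbon of the six-membered aromatic ring of carbon only. Compound 3 `Oc1ccc(C2C=C(n3nc(-c4ccccc4)nc3-c3ccccc3)N=C(S)N2)cc1` differs from compound 2 by hydroxy in place of furan-2-yl on an aromatic carbon. One earlier swap at this position left the minimum effective dose unchanged, so no step beyond the scatter is expected here either, no change at the digits printed from compound 2 to compound 3 (within the scatter). Compound 3 is therefore estimated at 300 mg/kg, with a range from 150 mg/kg to 600 mg/kg.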

Compound 3, minimum effective dose: 300 mg/kg
Compound 3: the middle estimate sits on the measured number at the digits printed; measured number inside the range.
By their numbers in this assay, from the lowest: compounds 1, 2 and 3 (each within the scatter of the next).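

In this assay hydroxy in place of furan-2-yl gives no change at the digits printed from compound 2 to compound 3 (within the scatter), and hydroxy in place of chloro gives no change at the digits printed from compound 1 to compound 3 (within the scatter). The earlier pair covered only chloro and furan-2-yl; this position now also shows the same reading with a group that brings a hydrogen-bond donor and no ring. Nothing at hand explains this sameness.

Going by these compounds, whether any substituent at this position moves the minimum effective dose stays open, as all three compounds read alike. An amine or a carboxylic acid here would test that.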